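This account rests on a few compounds, and the source may have more. Where it says the series, first, only, none or still open, it means among the compounds named here.

The series shares the core seen in compound 1 `CC(C(=O)NCc1ccc(Cl)c(Cl)c1)c1ccc(NS(C)(=O)=O)c(F)c1` and varies the group on a saturated chain carbon bound to an amide-type nitrogen. In an assay on CHO cells for displacement of a labelled ligand from transient receptor potential cation channel subfamily V member 1 (Rattus norvegicus) (a lower number here means a stronger inhibitor, a higher number a weaker inhibitor), compound 1 gives 200 nM. Compound 2 `Cc1ccc(CNC(=O)C(C)c2ccc(NS(C)(=O)=O)c(F)c2)cc1` gives 3100 nM in this assay, the highest of the three numbers, while compound 3 `CC(C(=O)NCc1ccc(C2CCCC2)cc1)c1ccc(NS(C)(=O)=O)c(F)c1` gives 93 nM. Both measured steps are large: a 16-fold higher number from compound 1 to compound 2 (1.19 log units; beyond the scatter) and a 33-fold lower number from compound 2 to compound 3 (1.52 log units; beyond the scatter). Compound 4 `CC(C(=O)NCCCc1ccc(Cl)cc1)c1ccc(NS(C)(=O)=O)c(F)c1` differs from compound 2 by 2-(4-chlorophenyl)ethyl in place of 4-methylphenyl on a saturated chain carbon bound to an amide-type nitrogen. The comparison of compound 1 with compound 2 bears on this most directly, because a 16-fold higher number from compound 1 to compound 2 (1.19 log units; beyond the scatter) shows that a phenyl carrying chlorine gave a markedly lower number than one carrying methyl. Going by the values given here, no measured pair tells what lengthening to a 2-(4-chlorophenyl)ethyl chain does, so the expected step is estimated at a 6.2-fold lower number from compound 2 to compound 4 (0.79 log units; beyond the scatter), downward and beyond the scatter but short of the full move back to compound 1. The estimate for compound 4 in this assay is 500 nM, with a range from 120 nM to 2500 nM.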

Compound 4, inhibition constant: 470 nM
Beside the measured number, compound 4's estimate is 1.1-fold (0.03 log units) above it; the range from low to high includes it.
By their numbers in this assay, from the lowest: compound 3; then compound 1; then compound 4; then compound 2.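

In this assay, the place on a saturated chain carbon bound to an amide-type nitrogen accepts the longer 2-(4-chlorophenyl)ethyl group, and a 6.6-fold lower number from compound 2 to compound 4 (0.82 log units; beyond the scatter) shows that this group gives a lower number than 4-methylphenyl. It does not fully match 3,4-dichlorophenyl, however, as a 2.4-fold higher number from compound 1 to compound 4 (0.37 log units; beyond the scatter) shows, so two chlorine-bearing groups at this place still differ beyond the scatter. The data shown offer no measured evidence on the reason for either step.

Going by these compounds, the step to compound 4 changes both the ring substituent and the chain, so the share of each remains open. A 4-chlorophenyl or a 2-(4-methylphenyl)ethyl group at this place would separate the two, and a 3-(4-chlorophenyl)propyl group would test a longer chain.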